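Sulfonamide aryl swap on the shared core of compound 2

A few compounds are considered here, and "the series" means these few. Any claim that something is new, unique, unknown or untested is made for them only; others in the source may bear on it.

In a functional assay on 143B cells (Homo sapiens) for antiproliferative activity, read by MTT assay, with a stated time of 48 h (on this read-out lower numbers stand for stronger inhibition and higher numbers for weaker inhibition), compound 2 `O=C(/C=C/c1cccc(NS(=O)(=O)c2cccc(Cl)c2)c1)c1nc2ccccc2[nH]1` gives 2510 nM, and compound 1 `Cc1cccc(C(=O)Nc2cccc(/C=C/C(=O)c3nc4ccccc4[nH]3)c2)c1` gives 4880 nM; the two values lie within the scatter of each other, so neither stands apart. Within the data shown here, the one measured step, a 1.9-fold lower number from compound 1 to compound 2 (0.29 log units; within the scatter), exchanges both the linker and the aryl group, so it bears only loosely on the change to compound 3 `Cc1ccccc1S(=O)(=O)Nc1cccc(/C=C/C(=O)c2nc3ccccc3[nH]2)c1`, which is 2-methylphenyl in place of 3-chlorophenyl on a sulfonyl sulfur. Among the measured compounds shown here, no measured step isolates an aryl swap on the sulfonyl sulfur. For compound 3 the expectation is therefore no step beyond the scatter, a 1.0-fold lower number from compound 2 to compound 3 (0.00 log units; within the scatter), with an estimate of 2500 nM in the range 1000 nM to 6500 nM.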

Compound 3, half-maximal inhibitory concentration: 4060 nM
The estimate for compound 3 lay 1.6-fold (0.21 log units) below the measured number, and the stated range covers the measured number.
By their numbers in this assay, from the lowest: compounds 2, 3 and 1 (each within the scatter of the next).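

In this assay, the aryl swap on the sulfonyl sulfur, 2-methylphenyl in place of 3-chlorophenyl, gives a 1.6-fold higher number from compound 2 to compound 3 (0.21 log units; within the scatter), so the two aryl groups are not told apart at this position. The linker comparison, a 1.2-fold lower number from compound 1 to compound 3 (0.08 log units; within the scatter), also stays within the scatter and does not separate (2-methylphenyl)sulfonyl from (3-methylphenyl)carbonyl on that nitrogen. No evidence is available to account for these values.

Still open, as far as these compounds go, is whether a 3-aminophenyl or 3-carboxyphenyl group, or a longer alkyl chain, on the sulfonyl sulfur would give a step beyond the scatter.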